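Thiophen-2-yl in place of 4-methylphenyl on compound 1

The source may report more compounds than this note shows. Statements on the series, on what has been measured and on what is new or still open speak of the compounds shown alone.

Measured in a functional assay on PC-3 cells (Homo sapiens) for cytotoxicity, read by WST assay, with a stated time of 72 h; a higher number here means a weaker inhibitor, a lower number a stronger inhibitor:
Compound 1 `Cc1ccc(C2(c3ccc(O)cc3)C(=O)Nc3c2ccc(F)c3F)cc1`: 0.8 nM.
Compound 2 `COc1ccc(C2(c3ccc(O)cc3)C(=O)Nc3c2ccc(F)c3F)cc1`: 2 nM; 2.2 nM; > 1000 nM (3 entries), entries that disagree.
Compound 3 `CCCCCOc1ccc(C2(c3ccc(O)cc3)C(=O)Nc3c2ccc(F)c3F)cc1`: > 1000 nM, a limit.

For the measured compounds named here, compound 1 holds the only single number in this small set. No single number stands for compound 2, given (the several entries of compound 2 in this assay, 2 nM; 2.2 nM; > 1000 nM (3 entries)). The next compound, compound 4 `O=C1Nc2c(ccc(F)c2F)C1(c1ccc(O)cc1)c1cccs1`, is not yet measured. The change leading to it is thiophen-2-yl in place of 4-methylphenyl on a saturated ring carbon.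

Going by the values given here, only one measured step bears on this, and only loosely. The step of an at least 1200-fold higher number from compound 1 to compound 3 (3.09 log units; beyond the scatter) is large, but it is pentyloxy in place of methyl on an aromatic carbon. It shows that a single change within the 4-methylphenyl group of compound 1 can carry the read-out to a limit. Among the compounds with values here, no measured step exchanges that whole ring. Within the data shown here, a moderate move towards a higher number in this assay is therefore expected, with a wide margin on the high side and no expectation of a step as large as the measured one.

The estimated step is a 6.3-fold higher number from compound 1 to compound 4 (0.80 log units; beyond the scatter). Compound 4 is expected at 5 nM, with an estimated range from 0.6 nM to 100 nM.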

Compound 4, half-maximal inhibitory concentration: 0.3 nM
Compound 4: middle estimate off by 17-fold (1.22 log units), on the high side; measured number outside the range, below it.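

Exchanging the whole ring on the saturated ring carbon in this assay gives a 2.7-fold lower number from compound 1 to compound 4 (0.43 log units; beyond the scatter), so the 4-methylphenyl group is not needed at this position for a low number, and thiophen-2-yl, with 5 heavy atoms in place of 7 and a sulfur in the ring, is accepted there. For the compounds shown here, the only earlier step at that group, an at least 1200-fold higher number from compound 1 to compound 3 (3.09 log units; beyond the scatter), was a change within the ring, pentyloxy in place of methyl, and it ended at a limit, so the two steps together show that this part of the series can move the read-out in both directions, and that lengthening a substituent and replacing the ring are different changes. Nothing measured in this set gives a reason for the lower number of compound 4.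

Open, as far as these compounds go, is whether this result belongs to thiophen-2-yl alone or extends to other rings at the same carbon, such as furan-2-yl or a saturated cyclohexyl group. Also open, from the compounds shown here alone, is how an amine or a carboxylic acid would read at this position, or a chain of intermediate length such as ethoxy on the 4-methylphenyl ring.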